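This account rests on a few compounds, and the source may have more. Where it says the series, first, only, none or still open, it means among the compounds named here.

Measured compounds:
Compound 1 `O=S(=O)(c1ccc(Cl)cc1)n1ccc2c(N3CCNCC3)cccc21` gives 2 nM in an assay on HeLa cells for displacement of a labelled ligand from 5-hydroxytryptamine receptor 6 (Homo sapiens); a lower number here means a stronger inhibitor, a higher number a weaker inhibitor.
Compound 2 `O=S(=O)(c1ccccc1Cl)n1ccc2c(N3CCNCC3)c(Cl)ccc21` gives 1 nM in this assay.

Compound 2 has the lower of the two numbers, yet compound 1 sits within the scatter of it, so the pair is not separated. Compound 3 `O=S(=O)(c1ccc(Cl)cc1)n1ccc2c(N3CCNCC3)c(Cl)ccc21` is the untested companion: it differs from compound 2 by 4-chlorophenyl in place of 2-chlorophenyl on a sulfonyl sulfur. Compound 1 carries the same 4-chlorophenyl and gives 2 nM, so no step beyond the scatter in this assay is expected in either direction. Compound 3 is therefore estimated at 1.5 nM, between 0.5 nM and 5 nM, a step of a 1.5-fold higher number from compound 2 to compound 3 (0.18 log units; within the scatter) that is expected to stay within the scatter.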

Compound 3, inhibition constant: 6.31 nM
Compound 3: middle estimate off by 4.2-fold (0.62 log units), on the low side; the whole stated range lies below it.
By their numbers in this assay, from the lowest: compounds 2 and 1 (each within the scatter of the next); then compound 3.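

With the chloro on the aromatic carbon of the core kept, 4-chlorophenyl in place of 2-chlorophenyl on the sulfonyl sulfur gives a 6.3-fold higher number from compound 2 to compound 3 (0.80 log units; beyond the scatter), so in this assay the place of the chlorine on this ring matters. With 4-chlorophenyl kept, chloro in place of hydrogen on that aromatic carbon gives a 3.2-fold higher number from compound 1 to compound 3 (0.50 log units; beyond the scatter), so this change also registers beyond the scatter. Nothing measured here accounts for either step.

The compounds shown leave open how chloro in place of hydrogen on that aromatic carbon reads with 2-chlorophenyl on the sulfonyl sulfur. They also leave open how an unsubstituted phenyl or a 2-methoxyphenyl would read there.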